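A few compounds are considered here, and "the series" means these few. Any claim that something is new, unique, unknown or untested is made for them only; others in the source may bear on it.

Compound 2 `CCCCCCCCCCCC(=O)OC[C@H](CSC[C@@H](N)C(=O)NCCCS(=O)(=O)O)OC(=O)CCCCCCCCCCC` stands at the higher end of the two numbers measured in an assay on HEK293 cells for agonist activity at Toll-like receptor 2 (Homo sapiens) (a higher number here means that more compound is needed for the effect, a lower number that less compound is needed), where compound 2 gives 5560 nM. Its nearest neighbour is compound 1 `CCCCCCCCCCCC(=O)OC[C@H](CSC[C@@H](N)C(=O)NC1(CO)CC1)OC(=O)CCCCCCCCCCC`, which in this assay gives 265 nM. The two differ in one place, and the step of a 21-fold higher number from compound 1 to compound 2 (1.32 log units; beyond the scatter) shows that exchanging the 1-(hydroxymethyl)cyclopropyl for the 3-sulfopropyl on the amide-type nitrogen cost a great deal.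

Compound 3 `CCCCCCCCCCCC(=O)OC[C@H](CSC[C@@H](N)C(=O)NCCOCCOCCOCCC(=O)O)OC(=O)CCCCCCCCCCC` keeps the shared core and changes the same region once more: 2-(2-(2-carboxyethoxy)ethoxy)ethoxy in place of sulfomethyl on a saturated chain carbon, two bonds along the chain from an amide-type nitrogen. For the measured compounds named here, only the step from compound 1 to compound 2 bears on this change, and it was large. It tells that what hangs from the amide-type nitrogen matters, but not which of the two ends of that step compound 3 will resemble, since neither measured compound carries the new group. The expectation for compound 3 is therefore a middling number with a wide range, which amounts to the step of a 2.8-fold lower number from compound 2 to compound 3 (0.44 log units; beyond the scatter). In this assay compound 3 is estimated at 2000 nM, between 400 nM and 10000 nM.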

Compound 3, half-maximal effective concentration: 900 nM
The estimate for compound 3 lay 2.2-fold (0.35 log units) above the measured number; measured number inside the range.
By their numbers in this assay, from the lowest: compound 1; then compound 3; then compound 2.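

In this assay, the change brings a 6.2-fold lower number from compound 2 to compound 3 (0.79 log units; beyond the scatter), so this position, on a saturated chain carbon two bonds along the chain from an amide-type nitrogen, can take the much larger 2-(2-(2-carboxyethoxy)ethoxy)ethoxy group without the number rising. The group that enters has 12 heavy atoms and the sulfomethyl that leaves has 5, so in this one pair a larger group goes with a lower number, and added size alone did not raise it. No measurement is available that explains this shift.

The step changes the chain length, the ether oxygens and the acidic end group all at once, so the compounds shown leave open which of these accounts for the lower number. A carboxymethyl group in place of sulfomethyl would test the end group on a short chain, while the same ether chain ending in a hydroxyl or an amine would test the end group on the long chain.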